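Adding a hydroxyethyl group to a weak benzimidazole acetic acid

This account rests on a few compounds, and the source may have more. Where it says the series, first, only, none or still open, it means among the compounds named here.

Measured compounds:
compound 1, `O=C(O)Cn1c(SCc2ccccc2Cl)nc2ccccc21`, 370 nM
compound 2, `COc1ccccc1CSc1nc2ccccc2n1CC(=O)O`, 1100 nM
compound 3, `COC(=O)c1ccccc1CSc1nc2ccccc2n1CC(=O)O`, 520 nM

In an assay on HEK293 cells for displacement of a labelled ligand from prostaglandin D2 receptor 2 (Homo sapiens) (a lower number here means a stronger inhibitor, a higher number a weaker inhibitor), compound 2 gives the highest of the three numbers. The step of a 3.0-fold higher number from compound 1 to compound 2 (0.47 log units; beyond the scatter) lies beyond the scatter, as does a 2.1-fold lower number from compound 2 to compound 3 (0.33 log units; beyond the scatter), while a 1.4-fold higher number from compound 1 to compound 3 (0.15 log units; within the scatter) stays within it. Compound 2 is therefore the weakest binder of this small set.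

Compound 4, `COc1ccc(C(C)O)cc1CSc1nc2ccccc2n1CC(=O)O`, differs from compound 2 in one place: 1-hydroxyethyl in place of hydrogen on an aromatic carbon.

Within the data shown here, none of the measured steps touches this position; all three swap the group that sits elsewhere on the same ring, and the largest of them is a 3.0-fold higher number from compound 1 to compound 2 (0.47 log units; beyond the scatter). Among the measured compounds shown here, there is thus no direct precedent, and the only guide is that single changes on this ring have moved the number by modest amounts in both directions. The 1-hydroxyethyl group brings a donor and an acceptor where compound 2 has only hydrogen, and a step of modest size in either direction, or none beyond the scatter, is equally plausible.

Compound 4 is expected to give about 900 nM in this assay, within a range of 350 nM to 2500 nM. This estimate corresponds to the step of a 1.2-fold lower number from compound 2 to compound 4 (0.09 log units; within the scatter).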

Compound 4, half-maximal inhibitory concentration: 2200 nM
Estimate against measurement, compound 4: 2.4-fold (0.39 log units) below; measured number inside the range.
By their numbers in this assay, from the lowest: compounds 1 and 3 (each within the scatter of the next); then compounds 2 and 4 (each within the scatter of the next).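

Compound 4 is the only compound shown with a group on this aromatic carbon, para to a methoxy group and meta to a large group, so it gives the first reading of this position. In this assay the step of a 2.0-fold higher number from compound 2 to compound 4 (0.30 log units; within the scatter) does not separate the two compounds, and 1-hydroxyethyl in place of hydrogen here therefore has no effect that this assay can resolve, in either direction. The data shown offer no evidence that would explain this outcome.

From the compounds shown here alone, a single substituent cannot show whether this carbon is insensitive to change in general, and it remains open whether an ethyl group, an amine, a carboxylic acid or a longer chain placed here would give a step beyond the scatter. Going by these compounds, it is also open whether 1-hydroxyethyl at this position would give a similar result with the chloro group of compound 1 or the methoxycarbonyl group of compound 3 in place of the methoxy group of compound 4.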